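Oxygen substituent on the saturated ring of compound 2

The source may report more compounds than this note shows. Statements on the series, on what has been measured and on what is new or still open speak of the compounds shown alone.

Among the compounds with values here, compound 2 `CN(C)C(=O)OC1CCN(c2ccc(-c3ccccc3Cl)nn2)CC1` gives the lowest of the two numbers seen so far in a functional assay on the whole organism with Mus musculus as the target; a higher number here means that more compound is needed for the effect, a lower number that less compound is needed: compound 2 gives 1.6 mg/kg, and the only neighbour, compound 1 `OC1CCN(c2ccc(-c3ccccc3Cl)nn2)CC1`, gives 38 mg/kg in this assay. Within the data shown here, the single measured step, a 24-fold lower number from compound 1 to compound 2 (1.38 log units; beyond the scatter), puts the dimethylcarbamoyl on the oxygen on a saturated carbon, and that step was large.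

Compound 3 `C/N=C(\S)OC1CCN(c2ccc(-c3ccccc3Cl)nn2)CC1` differs from compound 2 as follows: a group of 4 heavy atoms (2 carbon, 1 nitrogen, 1 sulfur; no ring) in place of a group of 5 heavy atoms (3 carbon, 1 nitrogen, 1 oxygen; no ring), on an oxygen on a saturated carbon. Among the measured compounds shown here, no measured pair covers this exchange, so the only bearing step is the one from compound 1 to compound 2, which shows that the oxygen substituent matters strongly in this assay. Compound 3 retains a substituent on that oxygen but one with a hydrogen-bond donor, which the dimethylcarbamoyl lacks. The expectation is that compound 3 lies between the unsubstituted compound 1 and compound 2, with the step of a 2.5-fold higher number from compound 2 to compound 3 (0.40 log units; beyond the scatter) estimated as a moderate rise in dose. Compound 3 is therefore expected to give about 4 mg/kg in this assay, within a range from 1.2 mg/kg to 15 mg/kg.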

Compound 3, dose for half-maximal effect: 20 mg/kg
For compound 3 the middle estimate is 5.0-fold (0.70 log units) below the measured one; measured number outside the range, above it.
By their numbers in this assay, from the lowest: compound 2; then compounds 3 and 1 (each within the scatter of the next).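

In this assay, a substituent on the oxygen on a saturated carbon does not by itself bring the low number seen with dimethylcarbamoyl: there is a 13-fold higher number from compound 2 to compound 3 (1.10 log units; beyond the scatter), whereas a 1.9-fold lower number from compound 1 to compound 3 (0.28 log units; within the scatter) leaves that pair indistinguishable. Among the three compounds, the large drop in dose therefore rests on dimethylcarbamoyl alone, and the new group keeps the number in the range of the compound with only a hydrogen on that oxygen. Within the data shown here, the exchange alters the heavy-atom count, brings in sulfur and adds a hydrogen-bond donor all at once, and no information on any property accompanies these numbers, so this result offers no account of the step.

The compounds shown leave open which part of dimethylcarbamoyl goes with the low number, a question that an acetyl or a diethylcarbamoyl on the same oxygen would address. They also leave open whether the sulfur or the hydrogen-bond donor goes with the higher number in compound 3, which a dimethylthiocarbamoyl at this place could help separate.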